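This account rests on a few compounds, and the source may have more. Where it says the series, first, only, none or still open, it means among the compounds named here.

In a physicochemical assay for solubility, at pH 7.4 (a higher number here means a more soluble compound, a lower number a less soluble compound), compound 1 (`Cc1cc(NC(=O)Nc2ccc(C)c(Cl)c2)c2ccccc2n1`) gives 300 nM. Among the measured compounds shown here, compound 2 (`Cc1cc(NC(=O)Nc2ccc(Cl)c(Cl)c2)c2ccccc2n1`) gives 300 nM, so compound 1 stands level with the only other compound measured so far. Compound 3 (`Cc1ccc(NC(=O)Nc2cc(C)nc3ccccc23)cc1`), still to be measured, differs from compound 1 in one place: hydrogen in place of chloro on an aromatic carbon. For the measured compounds named here, only one measured step is available to guide the expectation, no change at the digits printed from compound 1 to compound 2 (within the scatter), with chloro in place of methyl on an aromatic carbon. That step bears on the new change only indirectly, since it exchanges one group for another, whereas here a chloro leaves and only a hydrogen enters. Going by the values given here, the data therefore hold no direct precedent for this change, and they fix no direction for it. Given the step seen for compound 2, only a small shift in this assay is expected, with a tentative lean upward. The estimated change is a 1.5-fold higher number from compound 1 to compound 3 (0.18 log units; within the scatter), which is not expected to go clearly beyond the scatter. The expected value for compound 3 is 450 nM, with an estimated range of 200 nM to 1100 nM.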

Compound 3, solubility: 1300 nM
The estimate for compound 3 lay 2.9-fold (0.46 log units) below the measured number; the whole stated range lies below it.
By their numbers in this assay, from the lowest: compounds 1 and 2 (each within the scatter of the next); then compound 3.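

In this assay, among the compounds shown here, hydrogen in place of chloro on the aromatic carbon ortho to a methyl group gives a 4.3-fold higher number from compound 1 to compound 3 (0.64 log units; beyond the scatter), the only step so far that lies beyond the scatter. The earlier step, chloro in place of methyl, gave no change at the digits printed from compound 1 to compound 2 (within the scatter), so exchanging one of these groups for the other had left the read-out level, whereas taking this chloro away and leaving only hydrogen does not. No measurement shown here accounts for the size of this step.

What the compounds leave open is whether this step reflects the loss of the chloro as such or would be matched by other groups on the same carbon, such as a fluoro, a methoxy group or an amine, none of which appears among them. As far as these compounds go, it also remains open whether hydrogen in place of chloro at this carbon would give a step of similar size with the second chloro of compound 2 in place, since a single step from compound 1 is all that bears on this change.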